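Urea-capped hydroxamate series: swapping the terminal aryl group

This account rests on a few compounds, and the source may have more. Where it says the series, first, only, none or still open, it means among the compounds named here.

Measured in a functional assay on MCF7 cells (Homo sapiens) for antiproliferative activity, read by MTT assay; a higher number here means a weaker inhibitor, a lower number a stronger inhibitor:
compound 1 `COc1cc2c(Oc3ccc(NC(=O)Nc4ccc(OC(F)(F)F)cc4)cc3)ccnc2cc1OCCCCCCC(=O)NO` gives 3200 nM
compound 2 `COc1cc2c(Oc3ccc(NC(=O)Nc4ccccc4C(F)(F)F)cc3)ccnc2cc1OCCCCCCC(=O)NO` gives 1080 nM
compound 3 `COc1cc2c(Oc3ccc(NC(=O)N/N=C/c4ccccc4)cc3)ccnc2cc1OCCCCCCC(=O)NO` gives 610 nM

Compound 2 holds the second highest of the three numbers. Its nearest neighbour is compound 3, and that pair is within the scatter: a 1.8-fold lower number from compound 2 to compound 3 (0.25 log units; within the scatter). Its furthest is compound 1, and that pair is beyond the scatter: a 3.0-fold lower number from compound 1 to compound 2 (0.47 log units; beyond the scatter).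

Compound 4 `COc1cc2c(Oc3ccc(NC(=O)NNC(=O)c4ccccc4F)cc3)ccnc2cc1OCCCCCCC(=O)NO` is the next member. Compared with compound 2 the difference is ((2-fluorophenyl)carbonyl)amino in place of 2-(trifluoromethyl)phenyl on an amide-type nitrogen. The entering group brings one hydrogen-bond donor and one hydrogen-bond acceptor where the leaving group had none.

Within the data shown here, two measured steps bear on this change, both replacing an aryl group on the same amide-type nitrogen with a nitrogen-containing group of similar size: a 5.2-fold lower number from compound 1 to compound 3 (0.72 log units; beyond the scatter) and a 1.8-fold lower number from compound 2 to compound 3 (0.25 log units; within the scatter). The first was beyond the scatter, the second within it. Starting from compound 2, the analogous move gave only a small change, so for compound 4 a step toward a lower number in this assay is expected, but probably not beyond the scatter: a 1.4-fold lower number from compound 2 to compound 4 (0.13 log units; within the scatter).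

Compound 4 is therefore estimated at 800 nM in this assay, with a range from 300 nM to 2500 nM.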

Compound 4, half-maximal inhibitory concentration: 3600 nM
The estimate for compound 4 lay 4.5-fold (0.65 log units) below the measured number; the whole stated range lies below it.
By their numbers in this assay, from the lowest: compounds 3 and 2 (each within the scatter of the next); then compounds 1 and 4 (each within the scatter of the next).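

In this assay, a nitrogen-linked group on the amide-type nitrogen does not by itself go with a lower number: ((2-fluorophenyl)carbonyl)amino in place of 2-(trifluoromethyl)phenyl gives a 3.3-fold higher number from compound 2 to compound 4 (0.52 log units; beyond the scatter), the opposite direction to the step into the group of compound 3. The two nitrogen-linked groups are also clearly separated at this position, with a 5.9-fold higher number from compound 3 to compound 4 (0.77 log units; beyond the scatter), so the earlier result for compound 3 does not carry over to every group attached through nitrogen. The replacement of 4-(trifluoromethoxy)phenyl gives a 1.1-fold higher number from compound 1 to compound 4 (0.05 log units; within the scatter), which leaves compound 1 and compound 4 indistinguishable in this assay despite their different terminal groups, and the hydrogen-bond donor and acceptor counted on the entering group therefore bring no gain over either aryl urea compound in this small set.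

Nothing available accounts for the size or direction of these steps. As far as these compounds go, it remains open whether the step from compound 2 to compound 4 follows the carbonyl or the fluorine, a question that a phenylcarbonylamino group without fluorine would address, while a carboxylic acid in place of the hydroxamic acid or a longer chain would test whether the same ranking holds elsewhere on the molecule.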